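Chloro for methyl beside an acetamido group on a weak scaffold

The source may report more compounds than this note shows. Statements on the series, on what has been measured and on what is new or still open speak of the compounds shown alone.

Of the compounds shown here, three have been tested in a functional assay on MCF7 cells (Homo sapiens) for cytotoxicity; on this read-out lower numbers stand for stronger inhibition and higher numbers for weaker inhibition. Compound 1 `CC(=O)Nc1ccc(-c2nc3c(O)cccc3s2)cc1C` gives 33000 nM. Compound 2 `Nc1ccc(-c2nc3ccccc3s2)cc1Cl` reaches only a limit of the assay, < 1 nM. Compound 3 `Cc1cc(-c2nc3ccccc3s2)ccc1N` likewise gives only a limit, < 1 nM. Going by the values given here, two of the three values therefore sit at the limit of < 1 nM in this assay, at which 2 of the 3 values shown sit, and the single read number belongs to compound 1.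

Compounds 3 and 2 differ in one place, (chloro in place of methyl on an aromatic carbon), and the step that the two limits leave unreadable from compound 3 to compound 2 cannot be read, since both ends are limits. Compound 4 `CC(=O)Nc1ccc(-c2nc3c(O)cccc3s2)cc1Cl` is not yet measured; it arises from compound 1 by chloro in place of methyl on an aromatic carbon. This is the same kind of change as from compound 3 to compound 2, but the surroundings differ: here the site is ortho to an acetamido group (4 heavy atoms) and meta to a large group, whereas there it was ortho to an amino group (1 heavy atom) and meta to a group of 9 heavy atoms. How the core of compound 1 differs from the core of compound 3 is not broken down here.

Among the compounds with values here, with the only comparable step unreadable, the expected step from compound 1 to compound 4 in this assay is a 1.1-fold lower number from compound 1 to compound 4 (0.04 log units; within the scatter), kept small. Compound 4 is estimated to give 30000 nM, between 8000 nM and 100000 nM.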

Compound 4, half-maximal inhibitory concentration: 56800 nM
Compound 4: middle estimate off by 1.9-fold (0.28 log units), on the low side, and the stated range covers the measured number.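

In this assay chloro in place of methyl on an aromatic carbon gives a 1.7-fold higher number from compound 1 to compound 4 (0.24 log units; within the scatter) and so leaves compound 1 and compound 4 indistinguishable on the core of compound 1. This shows that, ortho to an acetamido group, this change does not move the number beyond the scatter on this one core, and a single pair shows no more than that. It does not show that the change carries over to the core of compound 3, where the same swap from compound 3 to compound 2 cannot be read because both ends are limits: the limit of < 1 nM in this assay, at which 2 of the 4 values shown sit.

The compounds shown leave open whether a bromo or a methoxy group at the same place would read any differently from methyl and chloro on the core of compound 1. They also leave open how an amine or a longer chain in place of the acetamido group would read on that core, and so what links the two cores.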